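The source may report more compounds than this note shows. Statements on the series, on what has been measured and on what is new or still open speak of the compounds shown alone.

Compound 1, `Nc1ccccc1NC(=O)c1ccc(CSC(=S)N2CCN(C(c3ccccc3)c3ccccc3)CC2)cc1`: 9.9% in a functional assay on MGC-803 cells (Homo sapiens) for antiproliferative activity, read by CCK-8 assay, with a stated time of 72 h, tested at 8 uM; a higher number here means a stronger effect of the compound at the concentration tested, a lower number a weaker effect
Compound 2, `Nc1ccccc1NC(=O)c1ccc(CSC(=S)N2CCN(c3ccc(Cl)cc3)CC2)cc1`: 17.2% in this assay
Compound 3, `CC1CCCCN1C(=S)SCc1ccc(C(=O)Nc2ccccc2N)cc1`: 86.9% in this assay

All three share the same core and differ in the group carried at one end of it. On the numbers shown, compound 2 holds the second of the three values. Its nearest neighbour is compound 1, whose number lies within the usual scatter of repeated measurements, so the two cannot be told apart. Compound 3 stands far beyond the scatter and shows a much stronger effect than compound 2.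

Compound 4, `Nc1ccccc1NC(=O)c1ccc(CSC(=S)N2CCN(c3ccccc3F)CC2)cc1`, has not yet been measured. It differs from compound 2 in one place: 2-fluorophenyl in place of 4-chlorophenyl on an amine nitrogen in a ring. Going by the values given here, no pair of measured compounds differs by a change of this kind, so nothing measured tells how large such a step is. Given that compound 2 gives 17.2% and the change exchanges one single-ring group for another of the same size, the step is expected to be small, in no clear direction, and to stay within the scatter. The expected step is a number 1.2 percentage points lower from compound 2 to compound 4 (within the scatter). Compound 4 is therefore estimated to give about 16%, with a range from 5% to 35%.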

Compound 4, a percentage reported as inhibition, at one concentration (the size of the read-out at that concentration, not a potency): 86.4%
Compound 4: middle estimate off by 70.4 percentage points, on the low side, and the stated range ends below it.
By their numbers in this assay, from the lowest: compounds 1 and 2 (each within the scatter of the next); then compounds 4 and 3 (each within the scatter of the next).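

In this assay, the exchange of 4-chlorophenyl for 2-fluorophenyl on the amine nitrogen in a ring turns out to be a large step (a number 69.2 percentage points higher from compound 2 to compound 4 (beyond the scatter)). The earlier compounds shown here gave no size for a change of this kind, and this one shows that the read-out at this position can respond strongly even when the count of features stays the same: both groups have 7 heavy atoms and one six-membered aromatic ring of carbon only, with no hydrogen-bond donors or acceptors and no net charge. Nothing shown here accounts for the size of the step.

This single step changes both the halogen and its place on the ring, so it cannot say which of the two matters, and 4-fluorophenyl and 2-chlorophenyl are the groups that would separate them. Plain phenyl and 2-methoxyphenyl also remain open, as they would show whether a halogen is needed at all and whether other groups on the same ring position give a similar read-out.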